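The source may report more compounds than this note shows. Statements on the series, on what has been measured and on what is new or still open speak of the compounds shown alone.

Compound 1 `Oc1ccc(-c2cc(-c3cccc(O)c3)cc(-c3cccc(O)c3)n2)cc1`, compound 2 `Oc1ccc(-c2cc(-c3cccc(O)c3)cc(-c3ccc(O)cc3)n2)cc1` and compound 3 `Oc1ccc(-c2cc(-c3cccc(O)c3)nc(-c3ccccc3O)c2)cc1` have been tested in a functional assay on DU-145 cells (Homo sapiens) for cytotoxicity, read by CCK-8 assay, with a stated time of 4 days; a higher number here means a weaker inhibitor, a lower number a stronger inhibitor. Compound 1 gives 1940 nM, compound 2 gives 1400 nM and compound 3 gives 3420 nM. From compound 1 to compound 2 the change is 4-hydroxyphenyl in place of 3-hydroxyphenyl on an aromatic carbon, which produced a 1.4-fold lower number from compound 1 to compound 2 (0.14 log units; within the scatter). How the core of compound 3 differs from the core of compound 1 is not broken down here. Compound 4 `Oc1ccc(-c2cc(-c3ccc(O)cc3)nc(-c3ccccc3O)c2)cc1` is not yet measured; it differs from compound 3 by 4-hydroxyphenyl in place of 3-hydroxyphenyl on an aromatic carbon. This is the same kind of change as that from compound 1 to compound 2, though here the place is meta to a 2-hydroxyphenyl group rather than meta to a 3-hydroxyphenyl group. The step expected from compound 3 to compound 4 is a 1.4-fold lower number from compound 3 to compound 4 (0.14 log units; within the scatter), resting on the earlier 1.4-fold lower number from compound 1 to compound 2 (0.14 log units; within the scatter). Compound 4 is therefore estimated at 2500 nM.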

Compound 4, half-maximal inhibitory concentration: > 50000 nM
Compound 4 was reported as a limit (the forecaster's own chance of this, stated with the estimate: 3%); middle value at least 20-fold (1.30 log units) from the limit.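

In this assay, putting 4-hydroxyphenyl in place of 3-hydroxyphenyl gave an at least 14-fold higher number from compound 3 to compound 4 (1.16 log units; beyond the scatter), and the change did not carry over from one core to the other: the same change on two cores in this assay, a 1.4-fold lower number (0.14 log units; within the scatter) from compound 1 to compound 2 and an at least 14-fold higher number (1.16 log units; beyond the scatter) from compound 3 to compound 4, at least 20-fold (1.30 log units) apart, beyond the scatter of two such steps.
Compound 4 gives > 50000 nM, which is a limit of the assay and not a number.
The two pairs show that the result of this change depends on the core that carries it, but they do not show which feature of the core matters or how a further core would respond.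

The compounds shown leave open whether a third core would follow the pair of compound 1 and compound 2 or that of compound 3 and compound 4. They also leave open what a methoxy group or an amine would do in place of the hydroxyl on the group that moved.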